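The compounds below may be only part of what the source reports. "The series", "measured", "known", "first", "only" and "open" are said of these compounds alone.

Among the compounds with values here, in a functional assay on HT-1080 cells (Homo sapiens) for cytotoxicity, read by MTT assay, with a stated time of 72 h (a lower number here means a stronger inhibitor, a higher number a weaker inhibitor), compound 2 `COc1cccc(/C=C2\CCC/C(=C\c3cc(Cl)cc(Cl)c3)C2=O)c1OC` gives 6100 nM, the lower of the two numbers so far, while compound 1 `COc1cccc(/C=C2\CCC/C(=C\c3ccc(Br)cc3)C2=O)c1OC` gives 13700 nM. Compound 3 `COc1cccc(/C=C2\CCC/C(=C\c3ccc(O)c(Cl)c3)C2=O)c1OC` carries 3-chloro-4-hydroxyphenyl in place of 3,5-dichlorophenyl on a double-bonded chain carbon bound to a double-bonded ring carbon. Within the data shown here, only one measured step bears on this place, a 2.2-fold lower number from compound 1 to compound 2 (0.35 log units; beyond the scatter), and it is modest. A change of similarly modest size, toward a higher number, is therefore expected. The expected step is a 1.5-fold higher number from compound 2 to compound 3 (0.17 log units; within the scatter). For compound 3 the estimated value is 9000 nM, with an expected range of 3500 nM to 22000 nM.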

Compound 3, half-maximal inhibitory concentration: 14300 nM
Beside the measured number, compound 3's estimate is 1.6-fold (0.20 log units) below it; measured number inside the range.
By their numbers in this assay, from the lowest: compound 2; then compounds 1 and 3 (each within the scatter of the next).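

In this assay, 3-chloro-4-hydroxyphenyl in place of 3,5-dichlorophenyl gives a 2.3-fold higher number from compound 2 to compound 3 (0.37 log units; beyond the scatter), so keeping one chlorine on the ring does not by itself hold the lower number. Set against 4-bromophenyl, the same group gives a 1.0-fold higher number from compound 1 to compound 3 (0.02 log units; within the scatter), which leaves 3,5-dichlorophenyl alone with the lower number among these three compounds. Nothing available explains this difference. The compounds shown leave open whether the second chlorine or the missing hydroxyl matters more, and how an amine or a carboxylic acid on this ring would read.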